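A few compounds are considered here, and "the series" means these few. Any claim that something is new, unique, unknown or untested is made for them only; others in the source may bear on it.

Three compounds share the core of compound 1 `CSc1nc(SC)c2ncn([C@@H]3C[C@@H](O)[C@H](CO)O3)c2n1`, and in a functional assay on B-95-8 cells (Cercopithecidae) with B-95-8 cell line (Saguinus oedipus) as the target (a higher number here means a weaker inhibitor, a lower number a stronger inhibitor), compound 1 gives 225 uM. In this assay compound 2 `CNc1nc(SC)nc2c1ncn2[C@@H]1C[C@@H](O)[C@H](CO)O1` reaches only a limit, > 300 uM. Within the data shown here, the one measured step, an at least 1.3-fold higher number from compound 1 to compound 2 (0.12 log units; that floor lies within the scatter), thus has a floor that sits within the scatter. In this assay compound 3 `CN(C)c1nc(Br)nc2c1ncn2[C@@H]1C[C@@H](O)[C@H](CO)O1` likewise stands at a limit, > 300 uM. That places compound 3 at the limit of > 300 uM in this assay, at which 2 of the 3 values shown sit, with no number of its own to build on. Compound 4 `CSc1nc(N(C)C)c2ncn([C@@H]3C[C@@H](O)[C@H](CO)O3)c2n1` differs from compound 3 by methylsulfanyl in place of bromo on an aromatic carbon. Among the measured compounds shown here, no measured step involves bromo or this change; the step from compound 1 to compound 2 concerns methylamino in place of methylsulfanyl and was no larger than the scatter allows. The step of an at least 1.2-fold lower number from compound 3 to compound 4 (0.07 log units; that floor lies within the scatter) is therefore expected to remain within the scatter, with a fair chance that only a limit is reported again. Compound 4 is estimated at 250 uM in this assay, within a range from 110 uM to 550 uM.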

Compound 4, concentration for 50% inhibition: 116 uM
The estimate for compound 4 lay 2.2-fold (0.33 log units) above the measured number; the range from low to high includes it.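

In this assay, the aromatic carbon between two ring nitrogen atoms now shows that the group there can matter: with the dimethylamino group held, methylsulfanyl in place of bromo gives an at least 2.5-fold lower number from compound 3 to compound 4 (0.41 log units; beyond the scatter). With methylsulfanyl held, the second methyl on the nitrogen also counts, as methyl in place of hydrogen gives an at least 2.5-fold lower number from compound 2 to compound 4 (0.41 log units; beyond the scatter). By contrast, dimethylamino in place of methylsulfanyl gives a 1.9-fold lower number from compound 1 to compound 4 (0.29 log units; within the scatter), so that exchange does not separate the two compounds.

On these data alone, the true size of the two steps beyond the scatter stays open, as each is only a floor that starts from a limit: the limit of > 300 uM in this assay, at which 2 of the 4 values shown sit. Also open is how ethylsulfanyl, a longer chain or a primary amine would compare with methylsulfanyl on this carbon.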